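Swapping the anilino substituent in a quinazoline-type cytotoxic series

A few compounds are considered here, and "the series" means these few. Any claim that something is new, unique, unknown or untested is made for them only; others in the source may bear on it.

Compound 3, `FC(F)(F)c1ccc(CSc2nc(Nc3cccc(Cl)c3)c3ccccc3n2)cc1`, is the starting point here. In a functional assay on MDA-MB-231 cells (Homo sapiens) for cytotoxicity, read by MTT assay, with a stated time of 72 h (on this read-out lower numbers stand for stronger inhibition and higher numbers for weaker inhibition), compound 3 gives 18000 nM, the lowest of the two plain numbers shown. Compound 1, `CCCCCCCCNc1nc(SCc2ccc(C(F)(F)F)cc2)nc2ccccc12`, gives 22300 nM in this assay, and the step of a 1.2-fold lower number from compound 1 to compound 3 (0.09 log units; within the scatter). Compound 2, `CCOc1ccccc1Nc1nc(SCc2ccc(C(F)(F)F)cc2)nc2ccccc12`, reaches only the assay limit of > 50000 nM in this assay, a limit rather than a number. The step of an at least 2.7-fold lower number from compound 2 to compound 3 (0.44 log units; beyond the scatter). Compound 4, `COc1ccc(Nc2nc(SCc3ccc(C(F)(F)F)cc3)nc3ccccc23)cc1`, carries the change (4-methoxyphenyl in place of 3-chlorophenyl on a nitrogen on an aromatic ring). Since an alkoxyphenyl group on this nitrogen gave only a limit for compound 2 (the limit of > 50000 nM in this assay, at which 1 of the 3 values shown sits), a modest move toward weaker inhibition is expected, as a 1.7-fold higher number from compound 3 to compound 4 (0.22 log units; within the scatter). Compound 4 is therefore estimated at 30000 nM, within 12000 nM to 80000 nM.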

Compound 4, half-maximal inhibitory concentration: 15700 nM
The estimate for compound 4 lay 1.9-fold (0.28 log units) above the measured number; the measured number falls inside the stated range.
By their numbers in this assay, from the lowest: compounds 4, 3 and 1 (each within the scatter of the next). At a limit, above all of these: compound 2.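

The change from 3-chlorophenyl to 4-methoxyphenyl on this nitrogen moves the number by no more than the scatter (a 1.1-fold lower number from compound 3 to compound 4 (0.06 log units; within the scatter)), and the same holds for octyl against 4-methoxyphenyl (a 1.4-fold lower number from compound 1 to compound 4 (0.15 log units; within the scatter)). An alkoxyphenyl group here therefore need not give the result seen with 2-ethoxyphenyl (an at least 3.1-fold lower number from compound 2 to compound 4 (0.50 log units; beyond the scatter)). Compound 2 remains a limit of the assay, not a number: the limit of > 50000 nM in this assay, at which 1 of the 4 values shown sits.

Still open, going by these compounds, is whether the weak result belongs to the ethoxy group or to its place on the ring, which 4-ethoxyphenyl or 2-methoxyphenyl would help separate. A 4-aminophenyl or 4-carboxyphenyl group on this nitrogen also remains untested among the compounds shown.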